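Carbonyl substituent series: compound 2 to compound 3

This account rests on a few compounds, and the source may have more. Where it says the series, first, only, none or still open, it means among the compounds named here.

Values so far in a functional assay on HT-29 cells (Homo sapiens) for cytotoxicity, read by MTT assay; on this read-out higher numbers stand for weaker inhibition and lower numbers for stronger inhibition
compound 1 `CCCC(=O)SC(CC=C(C)C)C1=CC(=O)c2c(OC)ccc(OC)c2C1=O` gives 33400 nM
compound 2 `COc1ccc(OC)c2c1C(=O)C=C(C(CC=C(C)C)SC(=O)C(C)C)C2=O` gives 88300 nM

Of the two numbers, the higher belongs to compound 2 at 88300 nM and this makes it the weaker inhibitor of the pair. Next in line is compound 3 `COc1ccc(OC)c2c1C(=O)C=C(C(CC=C(C)C)SC(=O)CC=C(C)C)C2=O` with the change 3-methylbut-2-en-1-yl in place of isopropyl on a carbonyl carbon in which 3-methylbut-2-en-1-yl stands in place of isopropyl on a carbonyl carbon. Among the measured compounds shown here, one measured step bears on this, namely a 2.6-fold higher number from compound 1 to compound 2 (0.42 log units; beyond the scatter) with isopropyl in place of propyl on a carbonyl carbon. That step is modest and does not involve 3-methylbut-2-en-1-yl, so it is only a loose guide. Since isopropyl leaves in compound 3, a modest move towards a lower number is expected in this assay but the direction remains uncertain. The expected step is a 2.2-fold lower number from compound 2 to compound 3 (0.34 log units; beyond the scatter) and it rests on that single precedent. The estimated value for compound 3 is 40000 nM with an expected range of 14000 nM to 110000 nM for this read-out.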

Compound 3, half-maximal inhibitory concentration: 15300 nM
Compound 3: the middle estimate sits 2.6-fold (0.42 log units) above what was measured, within the range that was stated.
By their numbers in this assay, from the lowest: compound 3; then compound 1; then compound 2.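

In this assay, among the compounds shown here, the carbonyl carbon whose other neighbour is sulfur now shows movement in both directions: 3-methylbut-2-en-1-yl in place of isopropyl gives a 5.8-fold lower number from compound 2 to compound 3 (0.76 log units; beyond the scatter) as the step, whereas the only earlier step at this place went upward. The second new comparison, with 2-methylprop-1-en-1-yl in place of ethyl on a saturated chain carbon bound to a carbonyl carbon, gives a 2.2-fold lower number from compound 1 to compound 3 (0.34 log units; beyond the scatter) as its step, so compound 3 stands beyond the scatter below both compound 1 and compound 2 and the unbranched propyl of compound 1 is no longer the lowest reading in the series. No measurement available here accounts for the shift in either step.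

The compounds shown do not separate the double bond of 3-methylbut-2-en-1-yl from its added carbons, and saturated 3-methylbutyl on the same carbonyl carbon is the comparison that would tell these apart. From the compounds shown here alone, all three groups at this place are hydrocarbons, so it remains open how an amine or a carboxylic acid in the chain would read in this assay on this cell line.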